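The source may hold more compounds than are shown below. What is called first, only, known or untested is meant among the compounds shown, and "the series" means these compounds.

Four compounds share one core and are compared in a functional assay on NALM-6 cells (Homo sapiens) for cytotoxicity, read by MTT assay, with a stated time of 48 h; on this read-out lower numbers stand for stronger inhibition and higher numbers for weaker inhibition. Compound 1 `O=C(Nc1cc(C(F)(F)F)ccc1Nc1ccc(Br)cc1)c1ccncc1` gives 51900 nM, and compound 2 `CCN(CC)c1ccc(C(F)(F)F)cc1NC(=O)c1ccncc1` gives 63600 nM. Among the compounds with values here, the single change (4-bromophenyl)amino in place of diethylamino on an aromatic carbon gives a 1.2-fold lower number from compound 2 to compound 1 (0.09 log units; within the scatter). Compound 3 `CCN(CC)c1ccc(C(F)(F)F)cc1NC(=O)c1cccnc1Cl` differs from compound 2 in its core by 2-chloropyridin-3-yl in place of pyridin-4-yl on a carbonyl carbon; in this assay compound 3 is reported only as "not active" (no number reported), and no single number stands for it. Compound 4 `O=C(Nc1cc(C(F)(F)F)ccc1Nc1ccc(Br)cc1)c1cccnc1Cl` has not been measured. It differs from compound 3 by (4-bromophenyl)amino in place of diethylamino on an aromatic carbon. This is the same kind of change as that from compound 2 to compound 1: the group that leaves and the group that enters are the same, but the place is told as ortho to a large group in one case and ortho to a group of 9 heavy atoms in the other. Since the earlier step from compound 2 to compound 1 lay within the scatter, compound 4 is expected to stay near where compound 3 stands, at a weak level, with a real chance that only a limit is reported. Compound 4 is estimated at 90000 nM, between 40000 nM and 200000 nM.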

Compound 4, half-maximal inhibitory concentration: 35700 nM
Estimate against measurement, compound 4: 2.5-fold (0.40 log units) above, outside the stated range (below it).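

In this assay, 2-chloropyridin-3-yl in place of pyridin-4-yl on a carbonyl carbon, with (4-bromophenyl)amino on the core, gives a 1.5-fold lower number from compound 1 to compound 4 (0.16 log units; within the scatter), so with that group present the change leaves the number within the scatter. The same change with diethylamino, and the steps that link compound 3 to compound 2 and to compound 4, cannot be read: compound 3 is reported only as "not active" (no number reported), so the change is read on one core alone, and its carrying over from one core to the other is not shown. No measurement offered here speaks to why these compounds behave as they do.

The compounds shown leave open how the number would respond to another group on the aromatic carbon that carries diethylamino or (4-bromophenyl)amino, such as morpholine or a longer alkyl chain. They also leave open a carboxylic acid in place of the trifluoromethyl group, and whether any such group would move the number beyond the scatter.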